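A few compounds are considered here, and "the series" means these few. Any claim that something is new, unique, unknown or untested is made for them only; others in the source may bear on it.

Of the compounds shown here, two of a shared core have been measured in a functional assay on CHO cells for agonist activity at Melanocyte-stimulating hormone receptor (Homo sapiens), read by a luciferase reporter, with a stated time of 4 h; on this read-out lower numbers stand for an effect already at smaller amounts and higher numbers for an effect only at larger amounts of compound. Compound 1, `O=C1C(Cc2n[nH]c3cc(F)ccc23)C(=O)N(c2ccccc2)C=CN1CC(=O)N1CCCCc2ccccc21`, gives in this assay 1.59 nM. Compound 2, `CC(C)N(C(=O)CN1C=CN(c2ccccc2)C(=O)C(Cc2n[nH]c3ccccc23)C1=O)c1ccccc1`, gives in this assay 708 nM. Compound 2 thus stands at the highest of the two numbers, and its nearest neighbour, compound 1, sits at a far lower number, a gap well beyond the scatter of repeated measurements. The two compounds differ from each other in more than one place, so their values cannot be read as the result of a single change.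

Compound 3, `CC(C)N(C(=O)CN1C=CN(c2ccccc2)C(=O)C(Cc2n[nH]c3cc(F)ccc23)C1=O)c1ccccc1`, is now to be measured in this assay. It differs from compound 2 in one respect: fluoro in place of hydrogen on an aromatic carbon. This is the same fluoro group that compound 1 carries on its own core. Because compound 1 gives 1.59 nM, a lowering of the number in moving from compound 2 to compound 3 is expected, though the other difference between compound 1 and compound 2 means the size of that effect remains uncertain. Compound 3 is therefore estimated to reach 250 nM, in the range 60 nM to 1000 nM, an expected step of a 2.8-fold lower number from compound 2 to compound 3 (0.45 log units; beyond the scatter).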

Compound 3, half-maximal effective concentration: 186 nM
Compound 3: middle estimate off by 1.3-fold (0.13 log units), on the high side; measured number inside the range.
By their numbers in this assay, from the lowest: compound 1; then compound 3; then compound 2.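

In this assay, fluoro in place of hydrogen on this aromatic carbon, meta to a fused ring and para to a fused ring, gives a 3.8-fold lower number from compound 2 to compound 3 (0.58 log units; beyond the scatter), so this single change on its own moves the number by a modest step. With the fluoro group present on both sides of the comparison, replacing the group on the carbonyl carbon gives a 120-fold higher number from compound 1 to compound 3 (2.07 log units; beyond the scatter), a large step that far exceeds the one seen for the fluoro change. No measurement among the data offers a reason for either step.

The compounds shown leave open whether the fluoro step would keep its size with the other group on the carbonyl carbon, and whether it is particular to fluoro, as the reading for chloro, methoxy or a nitrile on the same aromatic carbon is unknown. It also remains open which feature of the group on the carbonyl carbon accounts for the large step, and where a simple amine such as dimethylamine in that place would fall.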